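Swapping methoxy for fluoro on the pendant ring

This account rests on a few compounds, and the source may have more. Where it says the series, first, only, none or still open, it means among the compounds named here.

Measured compounds:
- compound 1 `COc1ccc(-c2cc(NNC(=O)Nc3cc(Cl)nc(Cl)c3)nc3c2cnn3C)cc1`: 520 nM
- compound 2 `COc1ccc(-c2cc(NNC(=O)Nc3cc(Cl)nc(Cl)c3)nc3c2c(C)nn3C)cc1`: 1020 nM
- compound 3 `Cn1nc(C(F)(F)F)c2c(-c3ccccc3)cc(NNC(=O)Nc3cc(Cl)nc(Cl)c3)nc21`: 940 nM

Among the compounds with values here, in an assay on isolated protein for binding affinity to sphingosine 1-phosphate receptor 2 (Homo sapiens), read by surface plasmon resonance (a higher number here means weaker binding, a lower number tighter binding), compound 2 gives the highest of the three numbers, but it stands close to compound 3 and only a small way from compound 1; the step of a 2.0-fold higher number from compound 1 to compound 2 (0.29 log units; within the scatter) is the one measured change, and it stays inside the scatter. Compound 4 `Cc1nn(C)c2nc(NNC(=O)Nc3cc(Cl)nc(Cl)c3)cc(-c3ccc(F)cc3)c12` differs from compound 2 in a single spot: fluoro in place of methoxy on an aromatic carbon. Within the data shown here, no measured pair shows this exact exchange. The nearest hint comes from compound 3, which carries a plain phenyl ring and a trifluoromethyl on the shared core and gives 940 nM, a number almost the same as that of compound 2; this pair is not a single-point step, so it only shows that altering the pendant ring region has not moved the numbers much so far. The expected step of a 1.0-fold lower number from compound 2 to compound 4 (0.01 log units; within the scatter) is therefore none beyond the scatter. Compound 4 is estimated at 1000 nM, with a likely range from 400 nM to 2500 nM.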

Compound 4, dissociation constant: 980 nM
Compound 4: middle estimate off by 1.0-fold (0.01 log units), on the high side; the range from low to high includes it.
By their numbers in this assay, from the lowest: compounds 1, 3, 4 and 2 (each within the scatter of the next).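

In this assay, within the data shown here, the exchange of 4-methoxyphenyl for 4-fluorophenyl gives a 1.0-fold lower number from compound 2 to compound 4 (0.02 log units; within the scatter), the first direct single-point reading at this position, which sits para to a large group. Methoxy counts as a hydrogen-bond acceptor and fluoro does not, yet on this core the step stays within the scatter, so the assay does not tell these two groups apart here. No measurement at hand explains why the two groups read alike. The compounds shown leave open whether an amine, a carboxylic acid or a longer chain at this position would move the number beyond the scatter. They also leave open whether the same exchange would read alike on the core of compound 1, which lacks the methyl of compound 2.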